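The compounds below may be only part of what the source reports. "The series", "measured", "known", "first", "only" and "open" are said of these compounds alone.

Measured so far:
- compound 1, `COc1cccc(-c2cc(O)c3cccnc3n2)c1`, 55 nM
- compound 2, `COc1cccc(-c2cc(O)c3c(C)ccnc3n2)c1`, 58.9 nM
- compound 3, `Cc1cnc2nc(-c3ccc(Cl)cc3)cc(O)c2c1`, 3020 nM

All three were tested in a functional assay on U-251 cells (Homo sapiens); a lower number here means a stronger inhibitor of growth, a higher number a weaker inhibitor of growth. Compound 3 gives the highest number of the three: its value lies 3020 nM, far beyond the scatter from both compound 1 and compound 2, so it is clearly the weakest growth inhibitor in this set. Compounds 1 and 2 differ from each other only by a methyl on an aromatic carbon, and that step, a 1.1-fold higher number from compound 1 to compound 2 (0.03 log units; within the scatter), changed nothing beyond the scatter.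

Compound 4, `COc1ccc(-c2cc(O)c3cc(C)cnc3n2)cc1`, has not been measured. It differs from compound 3 in one place: methoxy in place of chloro on an aromatic carbon. The methoxy sits on an aromatic carbon of the carbon-only six-membered ring, para to a large group. For the measured compounds named here, no measured step matches this exchange, so the only direct step known, from compound 1 to compound 2, does not bear on it. What the numbers do show is that compounds 1 and 2, which also carry a methoxy on that ring, both give low values, while the chloro-bearing compound 3 gives a high one. The estimate for compound 4 is therefore a number expected to fall below compound 3, with an expected step of a 3.8-fold lower number from compound 3 to compound 4 (0.58 log units; beyond the scatter), but with wide uncertainty. Compound 4 is expected to give about 800 nM, in a range from 150 nM to 4000 nM.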

Compound 4, concentration for 50% growth inhibition: 4170 nM
For compound 4 the middle estimate is 5.2-fold (0.72 log units) below the measured one, outside the stated range (above it).
By their numbers in this assay, from the lowest: compounds 1 and 2 (each within the scatter of the next); then compounds 3 and 4 (each within the scatter of the next).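

In this assay, putting methoxy in place of chloro on an aromatic carbon of a six-membered aromatic ring of carbon only, para to a large group, gives a 1.4-fold higher number from compound 3 to compound 4 (0.14 log units; within the scatter), so this read-out cannot tell the two groups apart at this place on this core. For the compounds shown here, this is the first direct reading of that exchange, as the only earlier step concerned a different change, methyl in place of hydrogen, and it shows that swapping chloro for methoxy here does not by itself bring the number down. No measurement at hand explains why the two groups cannot be told apart here.

The compounds shown leave open whether any other group at this same place, such as an amine, a carboxylic acid or a longer chain like butoxy, would give a number clearly different from those of chloro and methoxy. They also leave open whether the exchange of chloro for methoxy would give a similar result on a core that differs from that of compound 3 in another place.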